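Fluoro for Chloro on an Aryl Piperazine

The compounds below may be only part of what the source reports. "The series", "measured", "known", "first", "only" and "open" are said of these compounds alone.

Compound 1 `Fc1ccc(N2CCN(Cc3ccn4c(CC5CC5)nnc4c3C(F)(F)F)CC2)c(Cl)c1` was tested in a functional assay on HEK293 cells for agonist activity at metabotropic glutamate receptor 1 (Homo sapiens), read by a luciferase reporter and cAMP accumulation (a higher number here means that more compound is needed for the effect, a lower number that less compound is needed), and gave > 10000 nM, which is a limit of the assay rather than a measured number. Compound 2 `Fc1ccc(C2CCN(Cc3ccn4c(CC5CC5)nnc4c3C(F)(F)F)CC2)c(F)c1` also sits at a limit in this assay, giving > 10000 nM. Where compound 1 stands is thus only a boundary, shared by every value so far (the limit of > 10000 nM in this assay, at which 2 of the 2 values shown sit). Compound 3 `Fc1ccc(N2CCN(Cc3ccn4c(CC5CC5)nnc4c3C(F)(F)F)CC2)c(F)c1` differs from compound 1 by fluoro in place of chloro on an aromatic carbon. Within the data shown here, no measured pair shows this change, and the step that the limit leaves unreadable from compound 1 to compound 3 is expected to be none beyond the scatter. Compound 3 is therefore estimated to give 15000 nM, within a range from 3000 nM to 60000 nM.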

Compound 3, half-maximal effective concentration: > 8000 nM
Compound 3: a limit, no number; the forecaster's own chance of this, stated with the estimate: 85%; the middle value lies beyond the limit too.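

Among these compounds, compound 1 and compound 3 both give limits, not numbers, in this assay, so no step between them can be read. The compounds shown leave open whether fluoro in place of chloro changes the concentration needed, and whether any of them has a measurable effect.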